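Diethylamino for amino in a long-chain amine series

The source may report more compounds than this note shows. Statements on the series, on what has been measured and on what is new or still open speak of the compounds shown alone.

Compound 1 `CCCCCCCCCCCCCCC(N)COCc1ccccc1` and compound 2 `CCCCCCCCCCCCCCC(COCc1ccccc1)N(CC)CC` share one core, and the only counted difference between them is diethylamino in place of amino on a saturated chain carbon bound to two saturated chain carbons. In an ADME assay on cells (Splenocyte, Mus musculus, strain BALB/c) for cytotoxicity, read by MTT assay, tested at 10 ug/mL (a lower number here means a weaker effect, a higher number a stronger effect of the compound at the concentration tested), compound 1 gives 12.2% and compound 2 gives 15.6%, so that a number 3.4 percentage points higher from compound 1 to compound 2 (within the scatter). Compound 3 `CCCCCCCCCCCCCCC(CN)NC(=O)OC(C)(C)C` carries another core; the difference between the core of compound 1 and the core of compound 3 is not broken down here. In this assay compound 3 gives 4.3%; its gap to compound 1 lies within the usual scatter, while its gap to compound 2 lies beyond it. Compound 4 `CCCCCCCCCCCCCCC(CN(CC)CC)NC(=O)OC(C)(C)C` is not yet measured. It differs from compound 3 by diethylamino in place of amino on a saturated chain carbon, two bonds along the chain from an amide-type nitrogen. Among the compounds with values here, this is the same kind of change as the one from compound 1 to compound 2, though not the same: there the place was a saturated chain carbon bound to two saturated chain carbons, here it is a saturated chain carbon two bonds along the chain from an amide-type nitrogen. Within the data shown here, for compound 4 the expected step is a number 3.7 percentage points higher from compound 3 to compound 4 (within the scatter), resting on a number 3.4 percentage points higher from compound 1 to compound 2 (within the scatter) as the only measured instance of this kind of change, and on compound 3 giving 4.3%. In this assay compound 4 is estimated at 8%, with a range from 0% to 18%.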

Compound 4, a percentage reported as activity, at one concentration (the size of the read-out at that concentration, not a potency): 7.8%
The estimate for compound 4 lay 0.2 percentage points above the measured number; the measured number falls inside the stated range.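

In this assay, diethylamino in place of amino on a saturated chain carbon, two bonds along the chain from an amide-type nitrogen, gives a number 3.5 percentage points higher from compound 3 to compound 4 (within the scatter). Within the data shown here, both steps lie within the scatter, so the agreement shows only that this change leaves no readable step on either core; it does not establish a real effect that travels from core to core, and two cores read at a single concentration cannot speak for the whole series or for potency. In this assay the change therefore reads alike on the two cores, with neither step beyond the scatter: the same change on two cores in this assay, a number 3.4 percentage points higher (within the scatter) from compound 1 to compound 2 and a number 3.5 percentage points higher (within the scatter) from compound 3 to compound 4, 0.1 percentage points apart, within the scatter of two such steps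

Still open, going by these compounds, is whether the same reading holds for other groups at this place, such as a cyclic amine like pyrrolidine or morpholine, or a carboxylic acid. Also open, on these data alone, is whether it survives on a core with a shorter or a longer chain, where the values may sit further from those seen here.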